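The source may hold more compounds than are shown below. What is called first, only, known or untested is meant among the compounds shown, and "the series" means these compounds.

In an ADME assay on HepG2 2.2.15 cells (Homo sapiens) for cytotoxicity (a lower number here means that less compound is tolerated, a higher number that more compound is tolerated), compound 1 `CC(C)(C)OC(=O)Nc1ncc(C(Oc2ccc(Cc3ccccc3)cc2)c2ccc(Cl)cc2)s1` gives > 50000 nM, which is a limit of the assay rather than a number. Compound 2 `Clc1ccc(C(Oc2ccc3cc(Br)ccc3c2)c2cnc(NCC3CCCCC3)s2)cc1` is recorded in this assay as "not toxic" (no number reported), without a figure. Neither compound therefore anchors the series with a number; the limit of > 50000 nM in this assay, at which 1 of the 2 values shown sits, is the only bound shown. Among the measured compounds shown here, no step between measured compounds exists, so no size of change can be read from the data. Compound 3 `CC(C)(C)C(=O)Nc1ncc(C(Oc2ccc3cc(Br)ccc3c2)c2ccc(Cl)cc2)s1` carries (tert-butyl)carbonyl in place of cyclohexylmethyl on a nitrogen on an aromatic ring. With nothing measured to lean on, no shift beyond the scatter is expected for compound 3, whose value in this assay is estimated at 50000 nM, between 20000 nM and 100000 nM.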

Compound 3, half-maximal cytotoxic concentration: "not toxic" (no number reported)
No number was reported for compound 3; there is nothing to compare the estimate with.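

Compound 2 and compound 3 both stand as "not toxic" without a figure, so no step can be read between them. What the change from cyclohexylmethyl to (tert-butyl)carbonyl does to tolerance stays open, with one bound shown: the limit of > 50000 nM in this assay, at which 1 of the 3 values shown sits.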